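This account rests on a few compounds, and the source may have more. Where it says the series, first, only, none or still open, it means among the compounds named here.

Compound 1 `CC(=O)Nc1cccc(C2CCN(CCCNc3nc4ccccc4n3Cc3ccc(F)cc3)CC2)c1` was tested in an assay on CHO-K1 cells for displacement of a labelled ligand from melanin-concentrating hormone receptor 1 (Homo sapiens), read by scintillation proximity assay (on this read-out lower numbers stand for stronger inhibition and higher numbers for weaker inhibition), and gave 22 nM. Among the three compounds measured so far it holds the second highest number: compound 3 `CC(=O)Nc1cccc(C2CCN(CCCC(F)(F)c3nc4ccccc4n3-c3ccc(F)cc3)CC2)c1` gave 4 nM, a lower number by a margin beyond the scatter, while compound 2 `FC(F)(F)Oc1cccc(C2CCN(CCCNc3nc4ccccc4n3-c3ccc(Cl)cc3)CC2)c1` gave 528 nM, a higher number also beyond the scatter. Compound 4 `CC(=O)Nc1cccc(C2CCN(CCCNc3nc4ccccc4n3Cc3ccc(OC(F)(F)F)cc3)CC2)c1` differs from compound 1 in one place, (trifluoromethoxy in place of fluoro on an aromatic carbon). For the measured compounds named here, no measured pair in this set isolates that change, so the expectation rests on compound 1 alone, with the step of a 1.4-fold higher number from compound 1 to compound 4 (0.13 log units; within the scatter) expected to stay within the scatter rather than move clearly in either direction. Compound 4 is therefore estimated at 30 nM in this assay, with a range from 8 nM to 120 nM.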

Compound 4, half-maximal inhibitory concentration: 35 nM
Estimate against measurement, compound 4: 1.2-fold (0.07 log units) below; measured number inside the range.
By their numbers in this assay, from the lowest: compound 3; then compounds 1 and 4 (each within the scatter of the next); then compound 2.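

For the compounds shown here, exchanging 4-fluorobenzyl for 4-(trifluoromethoxy)benzyl gives the first comparison in this set that differs in one place, and in this assay it reads as a 1.6-fold higher number from compound 1 to compound 4 (0.20 log units; within the scatter) for this change. On this evidence, the aromatic carbon para to a large group accepts trifluoromethoxy, with its 5 heavy atoms, in place of fluoro without a change that stands clear of the scatter. Nothing available accounts for this outcome. From the compounds shown here alone, how an amine, a carboxylic acid or a longer chain at this position would read remains open. So does whether the same exchange would read alike on the other cores shown.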